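Bromo for chloro in a bis-chalcone biphenyl series

The source may report more compounds than this note shows. Statements on the series, on what has been measured and on what is new or still open speak of the compounds shown alone.

Working notes on a small set of bis-enone phenols. In an ADME assay on HEK293 cells (Homo sapiens) for cytotoxicity, read by MTT assay, with a stated time of 24 h (on this read-out higher numbers stand for weaker inhibition and lower numbers for stronger inhibition), compound 1 `Cc1cc(O)c(C(=O)/C=C/c2ccccc2)c(-c2ccc(Cl)cc2)c1C(=O)/C=C/c1ccccc1` gives 5000 nM. Compound 3 `COc1ccc(/C=C/C(=O)c2c(C)cc(O)c(C(=O)/C=C/c3ccc(OC)c(OC)c3)c2-c2ccc(OCc3ccccc3)cc2)cc1OC`, carrying dimethoxy-substituted cinnamoyl arms and a benzyloxyphenyl group, gives 30000 nM in this assay. Compound 2 `Cc1cc(O)c(C(=O)/C=C/c2ccc(Cl)cc2)c(-c2ccc(Cl)cc2)c1C(=O)/C=C/c1ccc(Cl)cc1`, in which all three pendant phenyl rings carry chloro, was reported in this assay as "not active" (no number reported), with no number attached; it therefore cannot be placed on the same scale as compound 1 or compound 3, and the only statement the data allow is that compound 2 fell outside the active range while compound 1 and compound 3 returned numbers.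

Compound 4 `Cc1cc(O)c(C(=O)/C=C/c2ccc(Cl)cc2)c(-c2ccc(Br)cc2)c1C(=O)/C=C/c1ccc(Cl)cc1` differs from compound 2 in one place: bromo in place of chloro on an aromatic carbon. Among the measured compounds shown here, no measured pair in this set shows the effect of such a halogen swap, so the size of the step is not known from the data. Given that compound 2 gave "not active" (no number reported), the expectation for compound 4 is that it too returns a weak or absent signal, with any difference no larger than the usual scatter in either direction. Compound 4 is estimated at 60000 nM in this assay, within 15000 nM to 250000 nM, and a report of no activity rather than a number is considered likely.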

Compound 4, half-maximal inhibitory concentration: 25000 nM
Beside the measured number, compound 4's estimate is 2.4-fold (0.38 log units) above it; the measured number falls inside the stated range.
By their numbers in this assay, from the lowest: compound 1; then compounds 4 and 3 (each within the scatter of the next).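

No step can be read from compound 2 to compound 4, since in this assay compound 4 gives 25000 nM while compound 2 carries no number. The compounds shown leave open how far bromo in place of chloro shifts the value on an otherwise identical structure. No supporting evidence bears on this result.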